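Swapping the nitro for fluorine on the sulfonyl aryl ring

This account rests on a few compounds, and the source may have more. Where it says the series, first, only, none or still open, it means among the compounds named here.

Measured so far:
- compound 1, `O=C(NCc1ccc(CNS(=O)(=O)c2ccc([N+](=O)[O-])cc2)cc1)c1ccc(F)cc1`: 1000 nM
- compound 2, `O=C(NCc1ccc(CNS(=O)(=O)c2ccc(CN3CCCC3)cc2)cc1)c1ccc(F)cc1`: 1 nM

In an assay on MDA-MB-231 cells for binding affinity to C-X-C chemokine receptor type 4 (Homo sapiens), read by fluorescence and microscopy, with stated times of 10 min and 30 min (on this read-out higher numbers stand for an effect only at larger amounts of compound and lower numbers for an effect already at smaller amounts), compound 1 gives 1000 nM, the highest of the two numbers recorded; its nearest neighbour is compound 2, with a 1000-fold lower number from compound 1 to compound 2 (3.00 log units; beyond the scatter). That single step, a large one, shows that what sits on the aromatic ring attached to the sulfonyl sulfur can move the read-out very far.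

Compound 3, `O=C(NCc1ccc(CNS(=O)(=O)c2cccc(F)c2)cc1)c1ccc(F)cc1`, has not yet been measured. It differs from compound 1 as follows: 3-fluorophenyl in place of 4-nitrophenyl on a sulfonyl sulfur. For the measured compounds named here, this change is not the same as the one from compound 1 to compound 2, where a (pyrrolidin-1-yl)methyl replaced the nitro; here the nitro is simply exchanged for fluorine at a different position of the ring. Going by the values given here, no measured pair covers a nitro-to-fluorine exchange, so the direction cannot be read from the data. With the sulfonyl aryl substituent shown to matter but no precedent for this particular change, compound 3 is expected to land near compound 1, the expected step being a 1.5-fold higher number from compound 1 to compound 3 (0.18 log units; within the scatter). The estimate for compound 3 in this assay is 1500 nM, within a range of 300 nM to 8000 nM.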

Compound 3, effective concentration (reported as EC, without a stated level of effect): 1000 nM
Compound 3: middle estimate off by 1.5-fold (0.18 log units), on the high side, and the stated range covers the measured number.
By their numbers in this assay, from the lowest: compound 2; then compounds 1 and 3 (each within the scatter of the next).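

In this assay the exchange of 4-nitrophenyl for 3-fluorophenyl on the sulfonyl sulfur gives no change at the digits printed from compound 1 to compound 3 (within the scatter) and so shows that this position does not respond to every change: a different group on the aromatic ring can leave the read-out where it was. Set against the large step of a 1000-fold lower number from compound 1 to compound 2 (3.00 log units; beyond the scatter) in the same assay, this shows that the effect depends on which group the ring carries, and that removing the nitro group does not by itself bring the number down, at least when 3-fluorophenyl is what replaces 4-nitrophenyl. Nothing available here explains why these two changes differ so much.

Still open, going by these compounds, is whether the low number of compound 2 needs the pyrrolidine ring of its (pyrrolidin-1-yl)methyl group, or whether an open-chain amine such as dimethylaminomethyl or a piperidine ring in the same place would serve as well. Also open is what a carboxylic acid on this aromatic ring would do to the read-out, since all three compounds shown carry either a neutral group or an amine there.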